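This account rests on a few compounds, and the source may have more. Where it says the series, first, only, none or still open, it means among the compounds named here.

Measured compounds in a functional assay on Jurkat cells (Homo sapiens) for inhibition, read by MTT assay, with a stated time of 72 h; on this read-out higher numbers stand for weaker inhibition of growth and lower numbers for stronger inhibition of growth:
- compound 1 `CN/C=N/c1cc(-c2ccccc2)nn1-c1ccccc1`: compound 1 gives > 50000 nM, a limit of the assay.
- compound 2 `CN/C(C)=N/c1cc(-c2ccccc2)nn1-c1ccccc1`: compound 2 gives > 50000 nM, a limit of the assay.

Compound 2 thus stands at the upper limit of this assay; no number for it is known, only that it is not read below that limit. The same is true of compound 1, so the step that the two limits leave unreadable from compound 1 to compound 2 cannot be sized, and both values sit at the limit of > 50000 nM in this assay, at which 2 of the 2 values shown sit.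

Compound 3 `CC/C(=N\c1cc(-c2ccccc2)nn1-c1ccccc1)NC` is not yet measured. It differs from compound 2 by methyl in place of hydrogen on a saturated chain carbon bound to a carbon with a double bond to nitrogen; cut one bond further out, the change reads methyl to ethyl. Within the data shown here, the only measured step, a step that the two limits leave unreadable from compound 1 to compound 2, concerns lengthening the same chain and is itself unreadable, so it gives no direction for the further lengthening in compound 3. Among the measured compounds shown here, no other measured step bears on this change.

The expectation is therefore that compound 3 will again be reported at the limit rather than as a number in this assay, with the estimated step that the limit leaves unreadable from compound 2 to compound 3 being no more than scatter. Compound 3 is estimated at 80000 nM, within 30000 nM to 300000 nM.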

Compound 3, concentration for 50% growth inhibition: > 50000 nM
Compound 3: only a limit was reported; the forecaster's own chance of this, stated with the estimate: 85%; the middle value does not contradict the limit.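

In this assay compound 3 gives > 50000 nM, a limit of the assay. No new step can be read among compound 1, compound 2 and compound 3, since all three stand at the same limit: the limit of > 50000 nM in this assay, at which 3 of the 3 values shown sit. The compounds shown leave open what size of effect, if any, the change from methyl to ethyl has on growth inhibition.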